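Adding Bromine to the Weakest Compound of the Set

This account rests on a few compounds, and the source may have more. Where it says the series, first, only, none or still open, it means among the compounds named here.

Compound 1 `COc1ccc(C2CC(c3ccccc3)=NN2C2=NC(=O)/C(=C3\C(=O)Nc4ccccc43)S2)cc1`: 3450 nM
Compound 2 `COc1ccc(C2CC(c3ccccc3)=NN2C2=NC(=O)/C(=C3\C(=O)Nc4ccc(Br)cc43)S2)cc1`: 390 nM
Compound 3 `COc1ccc(C2=NN(C3=NC(=O)/C(=C4\C(=O)Nc5ccccc54)S3)C(c3ccc(OC)cc3)C2)cc1`: 89200 nM

In a functional assay on cells (Cancer cell lines, Homo sapiens) for cytotoxicity, read by sulforhodamine B assay, with a stated time of 48 h (on this read-out lower numbers stand for stronger inhibition of growth and higher numbers for weaker inhibition of growth), compound 3 gives the highest number of the three measured compounds, so it inhibits growth least. Compound 1 stands nearest to it, and the gap between them is a 26-fold higher number from compound 1 to compound 3 (1.41 log units; beyond the scatter); compound 2 lies furthest away. Compound 4 `COc1ccc(C2=NN(C3=NC(=O)/C(=C4\C(=O)Nc5ccc(Br)cc54)S3)C(c3ccc(OC)cc3)C2)cc1` differs from compound 3 in one place: bromo in place of hydrogen on an aromatic carbon. The same change has been measured once before, and that step was an 8.8-fold lower number from compound 1 to compound 2 (0.95 log units; beyond the scatter), a modest but clear improvement. For the measured compounds named here, that single step is the only guide here, so a drop of similar size is expected, in the direction of stronger growth inhibition. Compound 4 is therefore estimated at 10000 nM, with a range of 3000 nM to 35000 nM, which would be a step of an 8.9-fold lower number from compound 3 to compound 4 (0.95 log units; beyond the scatter).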

Compound 4, concentration for total growth inhibition: 405 nM
The estimate for compound 4 lay 25-fold (1.39 log units) above the measured number; the measured number lies below the stated range.
By their numbers in this assay, from the lowest: compounds 2 and 4 (each within the scatter of the next); then compound 1; then compound 3.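

The gain from bromo on this aromatic carbon depends on the core, with a 220-fold lower number from compound 3 to compound 4 (2.34 log units; beyond the scatter) against a much smaller earlier step: the same change on two cores in this assay, an 8.8-fold lower number (0.95 log units; beyond the scatter) from compound 1 to compound 2 and a 220-fold lower number (2.34 log units; beyond the scatter) from compound 3 to compound 4, 25-fold (1.40 log units) apart, beyond the scatter of two such steps

The added methoxy, so costly without bromo, makes no difference beyond the scatter once bromo is present, with a 1.0-fold higher number from compound 2 to compound 4 (0.02 log units; within the scatter): the same change on two cores in this assay, a 26-fold higher number (1.41 log units; beyond the scatter) from compound 1 to compound 3 and a 1.0-fold higher number (0.02 log units; within the scatter) from compound 2 to compound 4, 25-fold (1.40 log units) apart, beyond the scatter of two such steps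

The compounds shown hold only hydrogen or bromo at this position, so how a chloro or an amine there would behave stays open. Also open, on these data alone, is whether an ethoxy in place of the added methoxy would lose its penalty in the same way once bromo is present.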